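The compounds below may be only part of what the source reports. "The series", "measured", "known", "first", "only" and "open" are said of these compounds alone.

Compound 1 `O=C(NCCSc1nonc1/C(=N/O)Nc1ccc(F)c(C(F)F)c1)C1CS(=O)(=O)C1` belongs to a small set examined in an ADME assay on isolated protein for pharmacokinetics, with UDP-glucuronosyltransferase 1A9 (Homo sapiens) as the target, read by LC-MS, with a stated time of 60 min, at 37 degrees C, tested at 1 uM, in the presence of a further agent that is not named here; a higher number here means that the compound lasts longer, a lower number that the compound disappears faster. In this assay compound 1 reaches only a limit, > 3 h, so no exact number stands for it (the limit of > 3 h in this assay, at which 1 of the 3 values shown sits). Two relatives are measured with numbers: compound 2 `NS(=O)(=O)CC(=O)NCCSc1nonc1/C(=N/O)Nc1ccc(F)c(Br)c1` gives 0.758 h, and compound 3 `NS(=O)(=O)NCCSc1nonc1/C(=N/O)Nc1ccc(F)c(Br)c1` gives 0.183 h; putting sulfamoyl in place of (sulfamoylmethyl)carbonyl on an amine nitrogen brings a 4.1-fold lower number from compound 2 to compound 3 (0.62 log units; beyond the scatter). Compound 4 `CC(C)(O)CC(=O)NCCSc1nonc1/C(=N/O)Nc1ccc(F)c(C(F)F)c1` differs from compound 1 elsewhere: a group of 5 heavy atoms (4 carbon, 1 oxygen; no ring) in place of a group of 6 heavy atoms (3 carbon, 2 oxygen, 1 sulfur; one four-membered non-aromatic ring with 1 hetero atom), on a carbonyl carbon. For the measured compounds named here, no measured step alters the substituent on that carbonyl carbon, so the one known step bears on this change only loosely, showing that the amide side chain can move the number. Compound 4 is expected to give 2 h, between 0.7 h and 3.5 h. The expected step is an at least 1.5-fold lower number from compound 1 to compound 4 (0.17 log units; that floor lies within the scatter).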

Compound 4, half-life: > 3 h
Compound 4: a limit, no number (the forecaster's own chance of this, stated with the estimate: 35%); at least 1.5-fold (0.17 log units) between middle value and limit.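

Compound 1 and compound 4 each give only a limit in this assay, not a number, so no step between them can be read: the limit of > 3 h in this assay, at which 2 of the 4 values shown sit.

Going by these compounds, whether the 2-hydroxy-2-methylpropyl group or the group it replaces gives the longer half-life stays open.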